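A few compounds are considered here, and "the series" means these few. Any claim that something is new, unique, unknown or untested is made for them only; others in the source may bear on it.

Working notes on the series in an assay on HEK-293T cells for displacement of a labelled ligand from corticotropin-releasing factor receptor 2 (Homo sapiens), read by scintillation counting, with a stated time of 2 h, tested at 1 uM; a higher number here means more inhibition at the concentration tested (going by the name of the read-out), a lower number less inhibition. The set has the same core throughout and varies only the aryl group on the ring nitrogen. Compound 1 `CCCCN(CC)c1cc(C)nc2c1NC(=O)CN2c1ccc(C)cc1Cl` stands as "not determined" (no result reported) in this assay. Compound 2 `CCCCN(CC)c1cc(C)nc2c1NC(=O)CN2c1ccc(C(C)C)cc1Br` gives 0.7% in this assay, which is no meaningful inhibition at the concentration tested. Compound 3 `CCCCN(CC)c1cc(C)nc2c1NC(=O)CN2c1ccc(Br)cc1Cl` likewise stands as "not determined" (no result reported) in this assay; together with compound 1 that makes two entries with no result, so compound 2 is the only measured point. Going by the values given here, no step between two measured compounds can be computed, and nothing about the direction of any structural change can be read from the data.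

The compound still to be measured is compound 4 `CCCCN(CC)c1cc(C)nc2c1NC(=O)CN2c1ccc(C)cc1Br`. It differs from compound 3 as follows: 2-bromo-4-methylphenyl in place of 4-bromo-2-chlorophenyl on a nitrogen on an aromatic ring in a ring

With compound 3 unmeasured, the step from compound 3 to compound 4 in this assay has no reference point. Compound 4 is a near neighbour of compound 2, sharing the 2-bromo-4-methylphenyl group's bromine and differing only in the second substituent on that ring. Among the compounds with values here, on the single result of compound 2, 0.7%, no inhibition beyond the scatter is expected for this class in this assay. Compound 4 is therefore expected to give about 3%, with a likely range from -8% to 20%.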

Compound 4, a percentage reported as inhibition, at one concentration (the size of the read-out at that concentration, not a potency): 5.5%
Estimate against measurement, compound 4: 2.5 percentage points below; low and high end bracket the measured number.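

In this assay, going by these compounds alone, methyl in place of isopropyl on an aromatic carbon gives a number 4.8 percentage points higher from compound 2 to compound 4 (within the scatter), the first step that can be read. Compound 2 at 0.7% and compound 4 at 5.5% both show little inhibition at the concentration tested, so with the bromine of the aryl group kept, this change of the second substituent does not separate the two compounds in this assay. No measurement in hand bears on why the pair reads alike.

Steps involving compound 1 or compound 3, including the one to compound 4, cannot be read, so the bromine and chlorine pattern of the aryl group remains uncompared. Within the data shown here, whether an amine or a carboxylic acid on that aromatic carbon would give inhibition clear of the scatter stays open, since methyl and isopropyl are the only groups there with a reading and both lie on the same 2-bromophenyl frame.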